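Alpha-ketooxazole series: trifluoroacetyl replacing pyrimidinyl

This account rests on a few compounds, and the source may have more. Where it says the series, first, only, none or still open, it means among the compounds named here.

Measured so far:
compound 1, `NC(=O)c1ccc(-c2cnc(C(=O)CCCCCCc3ccccc3)o2)nc1`, 1.2 nM;
compound 2, `O=C(CCCCCCc1ccccc1)c1ncc(-c2ccncn2)o1`, 2.3 nM.

Both were run in an assay (Rattus norvegicus) for inhibition of Fatty-acid amide hydrolase 1 (Homo sapiens); on this read-out higher numbers stand for weaker inhibition and lower numbers for stronger inhibition. Compound 2 gives the higher of the two numbers, but the step of a 1.9-fold higher number from compound 1 to compound 2 (0.28 log units; within the scatter) is within the scatter, so the two compounds are not separated on this read-out.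

Compound 3, `O=C(CCCCCCc1ccccc1)c1ncc(C(=O)C(F)(F)F)o1`, has not been measured. It differs from compound 2 in one place: (trifluoromethyl)carbonyl in place of pyrimidin-4-yl on an aromatic carbon. Among the measured compounds shown here, no measured step bears on this change; the only step recorded swaps one six-membered aromatic ring for another on the same position and is within the scatter, so it says nothing about replacing the ring with a (trifluoromethyl)carbonyl group. The expected step of a 2.2-fold higher number from compound 2 to compound 3 (0.34 log units; beyond the scatter) in this assay is therefore set near zero with a wide range. Compound 3 is estimated at 5 nM, between 0.5 nM and 60 nM.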

Compound 3, inhibition constant: 4 nM
Estimate against measurement, compound 3: 1.3-fold (0.10 log units) above; low and high end bracket the measured number.
By their numbers in this assay, from the lowest: compounds 1, 2 and 3 (each within the scatter of the next, the first and the last beyond it).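

At the aromatic carbon next to the ring oxygen, a group with no ring now stands where only six-membered aromatic rings stood before: in this assay, (trifluoromethyl)carbonyl and pyrimidin-4-yl are not separated, with a 1.7-fold higher number from compound 2 to compound 3 (0.24 log units; within the scatter). Against 5-carbamoylpyridin-2-yl the same group does show a difference, a 3.3-fold higher number from compound 1 to compound 3 (0.52 log units; beyond the scatter), so an aromatic ring at this position is not required for inhibition of this order, although that swap carries a modest step. Nothing on hand accounts for either step.

Still open, on these data alone, is whether the carbonyl itself matters at this position, which a carboxylic acid, a methyl ester or a nitrile there would test. Also open, as far as these compounds go, is how a simple amine at this position, or a longer chain on the ketone, would read.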